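Furan-3-yl for furan-2-yl on a dihydropyrimidinone core

A few compounds are considered here, and "the series" means these few. Any claim that something is new, unique, unknown or untested is made for them only; others in the source may bear on it.

Measured compounds:
compound 1 `CC(=O)C1=C(C)NC(=O)NC1c1ccoc1`: 15%
compound 2 `CC1=C(C(=O)NC(C)C)C(c2ccco2)NC(=O)N1`: 2%

Compound 2 stands lowest of the two numbers in an assay on membranes from HEK293 cells for displacement of a labelled ligand from adenosine receptor A2b (Homo sapiens), read by scintillation counting, with a stated time of 30 min, tested at 1 uM; on this read-out lower numbers stand for less inhibition and higher numbers for more inhibition at the one concentration tested (going by the name of the read-out); compound 1 gives 15%, a number beyond the scatter above compound 2. Within the data shown here, no pair differing in one place has been measured, so no single step is known. Compound 3 `CC1=C(C(=O)NC(C)C)C(c2ccoc2)NC(=O)N1` differs from compound 2 by furan-3-yl in place of furan-2-yl on a saturated ring carbon. Compound 1 also carries furan-3-yl, but differs from compound 2 in more than one place. A small rise is expected, a number 6 percentage points higher from compound 2 to compound 3 (within the scatter), close to the scatter. Compound 3 is estimated at 8%, between 0% and 22%.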

Compound 3, a percentage reported as inhibition, at one concentration (the size of the read-out at that concentration, not a potency): 3%
For compound 3 the middle estimate is 5 percentage points above the measured one, within the range that was stated.
By their numbers in this assay, from the lowest: compounds 2 and 3 (each within the scatter of the next); then compound 1.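

In this assay, furan-3-yl in place of furan-2-yl on the saturated ring carbon gives a number 1 percentage points higher from compound 2 to compound 3 (within the scatter) and so does not separate the two furan attachments at this position. Isopropylamino in place of methyl on the carbonyl carbon gives a number 12 percentage points lower from compound 1 to compound 3 (beyond the scatter) as the one step here that lies beyond the scatter. Nothing available explains either step. Still open, from the compounds shown here alone, is how furan-2-yl behaves with methyl on the carbonyl carbon. Also open, going by these compounds, is whether a phenyl ring on the saturated ring carbon, or a longer chain on the carbonyl carbon, would change the number.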